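Fluoro in Place of Bromo on an Inactive Scaffold

A few compounds are considered here, and "the series" means these few. Any claim that something is new, unique, unknown or untested is made for them only; others in the source may bear on it.

Compound 1 `C=C1C[C@]23C[C@@]1(O)CC[C@H]2c1ccc(OS(=O)(=O)c2ccc(C)cc2)c(C)c1[C@@H]3Cn1cc(-c2ccc(Br)cc2)nn1` reaches only a limit in a functional assay on A549 cells (Homo sapiens) for cytotoxicity, read by MTT assay, with a stated time of 4 days; a higher number here means a weaker inhibitor, a lower number a stronger inhibitor: > 20000 nM.
Compound 2 `C=C1C[C@]23C[C@@]1(O)CC[C@H]2c1cc(Br)c(O)c(C)c1[C@@H]3Cn1cc(-c2ccc(C)cc2)nn1` likewise gives only a limit in this assay: > 20000 nM.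
Compound 3 `Cc1ccc(S(=O)(=O)Oc2ccc3c(c2C)[C@H](Cn2cc(-c4ccc(Br)cc4)nn2)[C@@]24CC(=O)[C@@](C)(CC[C@@H]32)C4)cc1` also gives only a limit in this assay: > 20000 nM.

Compound 1 stands nowhere in particular on a scale: it sits at the limit of > 20000 nM in this assay, at which 3 of the 3 values shown sit, and no measured pair differs in a single place, so no step size has yet been observed among these compounds. Compound 4 `C=C1C[C@]23C[C@@]1(O)CC[C@H]2c1ccc(OS(=O)(=O)c2ccc(C)cc2)c(C)c1[C@@H]3Cn1cc(-c2ccc(F)cc2)nn1` differs from compound 1 by fluoro in place of bromo on an aromatic carbon. Given (the limit of > 20000 nM in this assay, at which 3 of the 3 values shown sit), the step that the limit leaves unreadable from compound 1 to compound 4 is expected to be none beyond the scatter. Compound 4 is expected most likely to return a limit again in this assay. The estimate for compound 4 is 25000 nM, with a range from 10000 nM to 60000 nM.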

Compound 4, half-maximal inhibitory concentration: > 20000 nM
Compound 4 ended at the assay's limit (the forecaster's own chance of this, stated with the estimate: 80%); the middle value is on the limit's open side.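

Among these compounds, compound 1 and compound 4 both stand at a limit, so no step from bromo to fluoro can be read: the limit of > 20000 nM in this assay, at which 4 of the 4 values shown sit.

Going by these compounds, what stays open is whether any compound of this kind gives a readable value in this assay and, if so, how bromo and fluoro would compare there.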